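Trimming the Amine Substituent of a Coumarin Propargylamine

The source may report more compounds than this note shows. Statements on the series, on what has been measured and on what is new or still open speak of the compounds shown alone.

Measured compounds in an ADME assay on isolated protein for inhibition of Amine oxidase [flavin-containing] A (Homo sapiens), read by fluorescence and Amplex Red, with stated times of 15 min and 20 min; a higher number here means a weaker inhibitor, a lower number a stronger inhibitor:
compound 1 `C#CCN(CCCOc1ccc2ccc(=O)oc2c1)Cc1ccc(OC)cc1` gives 60000 nM
compound 2 `C#CCN(CCCCOc1ccc2ccc(=O)oc2c1)Cc1ccc(C(C)C)cc1` gives 35400 nM

Compound 1 holds the higher of the two numbers in this assay, but compound 2 sits within the scatter of it, so the two are not distinguished. Compound 3 `C#CCN(C)CCCOc1ccc2ccc(=O)oc2c1` differs from compound 1 by hydrogen in place of 4-methoxyphenyl on a saturated chain carbon bound to an amine nitrogen. For the measured compounds named here, no measured pair shows this change, so its size is unknown; a modest step toward a weaker inhibitor, a 1.5-fold higher number from compound 1 to compound 3 (0.18 log units; within the scatter), is expected. Compound 3 is therefore estimated at 90000 nM in this assay, within a range from 25000 nM to 350000 nM.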

Compound 3, half-maximal inhibitory concentration: 36900 nM
Compound 3: the middle estimate sits 2.4-fold (0.39 log units) above what was measured; the range from low to high includes it.
By their numbers in this assay, from the lowest: compounds 2, 3 and 1 (each within the scatter of the next).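

In this assay, hydrogen in place of 4-methoxyphenyl on a saturated chain carbon bound to an amine nitrogen, which reads as 4-methoxybenzyl to methyl, gives a 1.6-fold lower number from compound 1 to compound 3 (0.21 log units; within the scatter). This position therefore takes the loss of 8 heavy atoms, including one six-membered aromatic ring, without the number leaving the scatter, so this assay does not tell the two substituents apart. Nothing measured at hand offers a reason for this result.

As far as these compounds go, it remains open whether another group here, such as ethyl, unsubstituted benzyl or a benzyl bearing a carboxylic acid, would move the number beyond the scatter.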